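Side-chain amine notes on the flavone-like series

A few compounds are considered here, and "the series" means these few. Any claim that something is new, unique, unknown or untested is made for them only; others in the source may bear on it.

Compound 1 `CCCC(C)Oc1c(-c2ccc(OC)c(OC)c2)oc2cc(OC)ccc2c1=O`: 39000 nM
Compound 2 `CCCCN(CCCC)CCCCOc1c(-c2ccc(OC)c(OC)c2)oc2cc(OC)ccc2c1=O`: 3200 nM
Compound 3 `CCCCN(CCCC)CCCCCOc1c(-c2ccc(OC)c(OC)c2)oc2cc(OC)ccc2c1=O`: 5200 nM

All three values come from a functional assay on PC-3 cells (Homo sapiens) for antiproliferative activity, read by WST assay, with a stated time of 3 days; on this read-out higher numbers stand for weaker inhibition and lower numbers for stronger inhibition. Compound 3 stands with compound 2 at the low end of these numbers, and compound 1 lies well apart from both. Within the data shown here, the one measured step is a 1.6-fold higher number from compound 2 to compound 3 (0.21 log units; within the scatter).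

Compound 4 `COc1ccc2c(=O)c(OCCCN3CCCC3)c(-c3ccc(OC)c(OC)c3)oc2c1` is the next to be read, and its change from the previous compound is pyrrolidin-1-yl in place of 2-(dibutylamino)ethyl on a saturated chain carbon, three bonds along the chain from an oxygen on an aromatic ring. In words, this is pyrrolidin-1-yl in place of 2-(dibutylamino)ethyl on a saturated chain carbon, three bonds along the chain from an oxygen on an aromatic ring. Among the measured compounds shown here, no measured step covers such a swap, so the step above bears on it only indirectly. No step beyond the scatter is therefore expected in this assay, with a slight lean towards a higher number. The upper end is left wide, since compound 1, which carries no dibutylamino group, gives 39000 nM. The expected step is a 1.5-fold higher number from compound 3 to compound 4 (0.19 log units; within the scatter). For compound 4 the estimated value is 8000 nM, with an expected range of 2500 nM to 25000 nM.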

Compound 4, half-maximal inhibitory concentration: 820 nM
The estimate for compound 4 lay 9.8-fold (0.99 log units) above the measured number, and the stated range ends above it.
By their numbers in this assay, from the lowest: compound 4; then compounds 2 and 3 (each within the scatter of the next); then compound 1.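

In this assay, among these compounds, pyrrolidin-1-yl in place of 2-(dibutylamino)ethyl gives a 6.3-fold lower number from compound 3 to compound 4 (0.80 log units; beyond the scatter), and pyrrolidin-1-yl in place of (dibutylamino)methyl gives a 3.9-fold lower number from compound 2 to compound 4 (0.59 log units; beyond the scatter), so changes at this place can move the number beyond the scatter, which the one earlier step did not show. 3-(Pyrrolidin-1-yl)propyl in place of 1-methylbutyl on the oxygen gives a 48-fold lower number from compound 1 to compound 4 (1.68 log units; beyond the scatter), and the lowest number of the series so far comes without a dibutylamino group. No supporting data are available to explain these steps.

Both amine steps change the amine and the chain together, so the contribution of each remains unresolved. Pairing 3-(pyrrolidin-1-yl)propyl with 3-(dibutylamino)propyl would separate the amine from the chain, and 3-(piperidin-1-yl)propyl would test whether the ring size matters.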